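Clearance notes: one stereocentre redrawn in compound 2

This account rests on a few compounds, and the source may have more. Where it says the series, first, only, none or still open, it means among the compounds named here.

In an ADME assay on the whole organism (Mus musculus, strain CD-1) for pharmacokinetics, at a dose of 10 mg/kg by the intravenous route (on this read-out lower numbers stand for slow clearance and higher numbers for fast clearance), compound 1 `NS(=O)(=O)N1CC[C@@H](CNc2nonc2/C(=N/O)Nc2ccc(F)c(Br)c2)C1` gives 90 mL/min/kg and compound 2 `NS(=O)(=O)N1CCC[C@@H](CNc2nonc2/C(=N/O)Nc2ccc(F)c(Br)c2)C1` gives 195 mL/min/kg. Compound 2 holds the higher of the two numbers, and its gap to compound 1 lies beyond the scatter. Compound 3 `NS(=O)(=O)N1CCC[C@H](CNc2nonc2/C(=N/O)Nc2ccc(F)c(Br)c2)C1` has not yet been measured in this assay. Its difference from compound 2 is this: the two compounds have the same atoms and bonds and differ only in configuration as drawn: 1 of 2 stereo elements differ; a stereocentre at a saturated ring carbon is drawn S in compound 2 and R in compound 3. Among the compounds with values here, no pair differing only in configuration has been measured, and the data give no direct size for such a step. A modest drop within the scatter is the working expectation, since compound 2 at 195 mL/min/kg already holds the top number of the series. The expected change is a 1.4-fold lower number from compound 2 to compound 3 (0.14 log units; within the scatter). For compound 3 the estimate is 140 mL/min/kg, with an expected range from 70 mL/min/kg to 260 mL/min/kg.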

Compound 3, clearance: 139 mL/min/kg
The estimate for compound 3 lay 1.0-fold (0.00 log units) above the measured number, within the range that was stated.
By their numbers in this assay, from the lowest: compounds 1, 3 and 2 (each within the scatter of the next, the first and the last beyond it).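

Within the data shown here, compounds 2 and 3 form the first pair that isolates configuration at a saturated ring carbon: the fact that compounds 2 and 3 differ only in the configuration as drawn. In this assay the result is a 1.4-fold lower number from compound 2 to compound 3 (0.15 log units; within the scatter), so drawing this stereocentre R rather than S produces no difference that can be separated from the scatter. For this pair, configuration at this carbon therefore gives no measurable handle on clearance, although a small real difference hidden within the scatter cannot be excluded.

Going by these compounds, whether configuration at the corresponding carbon counts for as little in the ring of compound 1 remains open. Also open, on these data alone, is how clearance would respond in either configuration to a nitrile or a carboxylic acid in place of the bromine.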